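The source may report more compounds than this note shows. Statements on the series, on what has been measured and on what is new or still open speak of the compounds shown alone.

Measured so far:
compound 1, `COC(=O)C1=C(C)N=C(C)/C(=C(/O)OC)C1c1c(F)cccc1Cl`: 7.59 nM
compound 2, `COC(=O)C1=C(C)N=C(C)/C(=C(\O)OC)C1c1ccccc1N`: 39800 nM

Compound 2 stands at the highest of the two numbers in a functional assay (muscle tissue) with Cavia porcellus as the target; a lower number here means that less compound is needed, a higher number that more compound is needed for the effect. For the measured compounds named here, its nearest neighbour is compound 1, which in this assay gives 7.59 nM, a far lower number than compound 2 and well beyond the scatter; no single-point step between the two is recorded, so only the two values themselves are compared here.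

Compound 3, `COC(=O)C1=C(C)N=C(C)/C(=C(\O)OC)C1c1cccc(I)c1`, has not yet been measured in this assay. It differs from compound 2 in one place: 3-iodophenyl in place of 2-aminophenyl on a saturated ring carbon.

The expectation for compound 3 is a large step downward in number in this assay, because compound 1, the other halogen-bearing member of the series, gives 7.59 nM. Compound 3 is therefore estimated at 20 nM, within a range of 2 nM to 200 nM; this corresponds to an expected step of a 2000-fold lower number from compound 2 to compound 3 (3.30 log units; beyond the scatter).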

Compound 3, half-maximal effective concentration: 41.7 nM
Estimate against measurement, compound 3: 2.1-fold (0.32 log units) below; the range from low to high includes it.
By their numbers in this assay, from the lowest: compound 1; then compound 3; then compound 2.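

In this assay, for the compounds shown here, 3-iodophenyl in place of 2-aminophenyl on the saturated ring carbon gives a 950-fold lower number from compound 2 to compound 3 (2.98 log units; beyond the scatter) in the only single-place step available so far, so the number at this position depends strongly on the aryl group carried there. Compound 3 keeps the shared core of compound 2 unchanged. The numbers of the two compounds still lie far apart. No measurement at hand gives a reason for the size of this step.

The change moves the substituent and replaces it in a single step, so the contribution of the place on the phenyl ring remains separate from that of the group itself. Also open, on these data alone, is how a 3-methoxyphenyl or 3-nitrophenyl group would read at this position.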